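The source may report more compounds than this note shows. Statements on the series, on what has been measured and on what is new or still open speak of the compounds shown alone.

Among the measured compounds shown here, compound 1 `CC(O)(C(=O)Nc1ccc(S(=O)(=O)c2ccccc2C#N)cc1)C(F)(F)F` stands at the higher of the two numbers known so far in a functional assay (Cavia porcellus) with sulfonylurea receptors; K-ATP channels (Homo sapiens) as the target (on this read-out lower numbers stand for stronger inhibition and higher numbers for weaker inhibition), where compound 1 gives 1100 nM. Compound 2 `CC(O)(C(=O)Nc1ccc(S(=O)(=O)c2ccccc2)c(O)c1)C(F)(F)F` gives 430 nM in this assay, a number that lies below that of compound 1 by more than the usual scatter. Compound 3 `COc1cccc(S(=O)(=O)c2ccc(NC(=O)C(C)(O)C(F)(F)F)cc2)c1` differs from compound 1 in one place: 3-methoxyphenyl in place of 2-cyanophenyl on a sulfonyl sulfur. For the measured compounds named here, no measured pair shows this change. The step of a 1.1-fold lower number from compound 1 to compound 3 (0.04 log units; within the scatter) is therefore expected to be small, no larger than the scatter, in either direction. For compound 3 the expected value in this assay is 1000 nM, with a range from 400 nM to 2500 nM.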

Compound 3, half-maximal inhibitory concentration: 16000 nM
For compound 3 the middle estimate is 16-fold (1.20 log units) below the measured one, outside the stated range (above it).
By their numbers in this assay, from the lowest: compound 2; then compound 1; then compound 3.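

In this assay, the group on a sulfonyl sulfur matters strongly: 3-methoxyphenyl in place of 2-cyanophenyl brings a 15-fold higher number from compound 1 to compound 3 (1.16 log units; beyond the scatter), although both groups have the same counts of heavy atoms and hydrogen-bond acceptors. Those counts therefore do not settle the number at this position. No measurement at hand explains the step. The compounds shown do not separate the change of substituent from the change in where it sits on the ring. As far as these compounds go, how a carboxylic acid or an amine would fare on that ring also remains open.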